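Carbamate to aroyl amide at the acylated valine nitrogen

The source may hold more compounds than are shown below. What is called first, only, known or untested is meant among the compounds shown, and "the series" means these compounds.

Measured so far in an assay on THP-1 cells for displacement of a labelled ligand from C-C chemokine receptor type 1 (Homo sapiens); a higher number here means a weaker inhibitor, a lower number a stronger inhibitor:
compound 1 `CC(C)C(NC(=O)Oc1ccccc1)C(=O)N1CCC(c2ccc(Cl)cc2)CC1` gives 265 nM
compound 2 `Cc1ccccc1C(=O)NC(CC(C)C)C(=O)N1CCC(c2ccc(Cl)cc2)CC1` gives 88 nM
compound 3 `CC(C)C(NC(=O)OCc1ccccc1)C(=O)N1CCC(c2ccc(Cl)cc2)CC1` gives 1080 nM

Compound 3 stands highest of the three numbers in this assay. Its nearest neighbour is compound 1, reached by a 4.1-fold higher number from compound 1 to compound 3 (0.61 log units; beyond the scatter), a modest step that is beyond the scatter. Among the measured compounds shown here, the gap to compound 2 is wider: compound 3 gives 1080 nM where compound 2 gives 88 nM; these two structures differ in more than one place, so no single step is drawn between them.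

Compound 4 `Cc1ccccc1C(=O)NC(C(=O)N1CCC(c2ccc(Cl)cc2)CC1)C(C)C` is not yet measured. It arises from compound 3 by 2-methylphenyl in place of benzyloxy on a carbonyl carbon. For the measured compounds named here, the only single step that touches the acyl group is the one from compound 1 to compound 3, and it is modest. Compound 4 carries the same acyl group as compound 2, differing from it only in the side chain, and the values of compound 2 and compound 3 show that the aroyl amide sits well below the carbamate. The step from compound 3 to compound 4 is therefore expected to be a clear drop, about a 7.2-fold lower number from compound 3 to compound 4 (0.86 log units; beyond the scatter). Compound 4 is expected to give about 150 nM in this assay, within 60 nM to 400 nM.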

Compound 4, half-maximal inhibitory concentration: 36 nM
The estimate for compound 4 lay 4.2-fold (0.62 log units) above the measured number; the whole stated range lies above it.
By their numbers in this assay, from the lowest: compound 4; then compound 2; then compound 1; then compound 3.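

With the isopropyl side chain held fixed, the carbonyl carbon on the amide-type nitrogen can now be compared directly in this assay: 2-methylphenyl in place of benzyloxy gives a 30-fold lower number from compound 3 to compound 4 (1.48 log units; beyond the scatter) and 2-methylphenyl in place of phenoxy gives a 7.4-fold lower number from compound 1 to compound 4 (0.87 log units; beyond the scatter), so among these three groups 2-methylphenyl ranks ahead of both carbamate groups. The side chain also matters with the acyl group held constant, as isopropyl in place of isobutyl gives a 2.4-fold lower number from compound 2 to compound 4 (0.39 log units; beyond the scatter), a smaller step than either acyl change. No measurement available here accounts for these steps.

It remains open whether the methyl group itself contributes, since plain benzoyl is not among the compounds shown. Also open, going by these compounds, is how this acyl position responds to an amine or carboxylic acid on the aromatic ring, and how the side chain responds to a tert-butyl or cyclohexyl group.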